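A shorter chain and the tolerance it may bring

The compounds below may be only part of what the source reports. "The series", "measured", "known", "first", "only" and "open" are said of these compounds alone.

Among the compounds with values here, compound 2 `CCCCCCCCNc1cncc(C(=O)NCc2ccccc2)n1` stands as the only member of this small set with a single number in an ADME assay on MDCK cells (Canis lupus familiaris) for cytotoxicity, read by microscopy, with a stated time of 6 days (a higher number here means that more compound is tolerated, a lower number that less compound is tolerated), where compound 2 gives 4000 nM. Compound 1 `CCCCCCCNc1cnc(C(=O)NCc2ccccc2)cn1` reaches only a limit of the assay, recorded in this assay as > 100000 nM. That limit is noted as the limit of > 100000 nM in this assay, at which 1 of the 3 values shown sits. Compound 3 `O=C(NCc1ccccc1)c1cnc(Cl)cn1` has no result in this assay, recorded as "not determined" (no result reported). Compound 4 `CCCCCNc1cncc(C(=O)NCc2ccccc2)n1` has not been measured yet, and it differs from compound 2 in one place: hydrogen in place of propyl on a saturated chain carbon, five bonds along the chain from a nitrogen on an aromatic ring. Within the data shown here, no step between two measured compounds is available, so no measured precedent sets the size of this change. Still, it is expected that the change will make compound 4 more tolerated, with a step estimated at a 7.5-fold higher number from compound 2 to compound 4 (0.88 log units; beyond the scatter), which would be a moderate rise beyond the usual scatter. Compound 4 is therefore expected to give about 30000 nM in this assay, with an estimated range from 8000 nM to 100000 nM.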

Compound 4, minimum cytotoxic concentration: 20000 nM
Estimate against measurement, compound 4: 1.5-fold (0.18 log units) above, within the range that was stated.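

The step gives this change its first measured size: in this assay, hydrogen in place of propyl on a saturated chain carbon, five bonds along the chain from a nitrogen on an aromatic ring, brings a 5.0-fold higher number from compound 2 to compound 4 (0.70 log units; beyond the scatter). The outer part of this chain therefore matters to how much compound is tolerated, and compound 4 still gives a single number, so the read-out is not exhausted at this position. The only limit in the set belongs to compound 1, and it is a limit and not a number: the limit of > 100000 nM in this assay, at which 1 of the 4 values shown sits.

On these data alone, whether tolerance keeps rising as the chain shortens further, or changes at all with a still shorter chain such as ethyl, stays open. Also open, as far as these compounds go, is how a chain ending in an amine or a carboxylic acid would behave at this position.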